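Dimethylamino in place of phenylsulfanyl on the shared core

A few compounds are considered here, and "the series" means these few. Any claim that something is new, unique, unknown or untested is made for them only; others in the source may bear on it.

Compound 2 `Cc1nn(C)c(Sc2ccccc2)c1/C=N/OCc1ccc(C(=O)OC(C)(C)C)cc1` gives 0.28 ug/mL in a functional assay on XF498 cells (Homo sapiens) for cytotoxicity (a higher number here means a weaker inhibitor, a lower number a stronger inhibitor), the lowest of the two numbers; compound 1 `Cc1nn(C)c(-n2cccc2)c1/C=N/OCc1ccc(C(=O)OC(C)(C)C)cc1` gives 2.67 ug/mL. Among the compounds with values here, the one measured step at this carbon, a 9.5-fold lower number from compound 1 to compound 2 (0.98 log units; beyond the scatter), is the only precedent. Compound 3 `Cc1nn(C)c(N(C)C)c1/C=N/OCc1ccc(C(=O)OC(C)(C)C)cc1` carries dimethylamino in place of phenylsulfanyl on an aromatic carbon. That precedent shows the group at this carbon moves this assay by a modest but real amount, and the present change removes the phenylsulfanyl that gave the lowest number, so a rise is expected rather than a further fall. The expected step is a 5.4-fold higher number from compound 2 to compound 3 (0.73 log units; beyond the scatter). Compound 3 is therefore estimated at 1.5 ug/mL, within 0.4 ug/mL to 6 ug/mL.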

Compound 3, half-maximal inhibitory concentration: 3.87 ug/mL
For compound 3 the middle estimate is 2.6-fold (0.41 log units) below the measured one; the measured number falls inside the stated range.
By their numbers in this assay, from the lowest: compound 2; then compounds 1 and 3 (each within the scatter of the next).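

In this assay, a 14-fold higher number from compound 2 to compound 3 (1.14 log units; beyond the scatter), so dimethylamino does not keep the low number seen with phenylsulfanyl on this aromatic carbon. Against the other nitrogen-linked group, the result is a 1.4-fold higher number from compound 1 to compound 3 (0.16 log units; within the scatter), which leaves phenylsulfanyl alone at the low end among these three compounds. No available evidence bears on why these groups separate in this way. Still open, as far as these compounds go, is whether the sulfur atom or the six-membered aromatic ring goes with the low number. Methylsulfanyl and phenoxy on this carbon would separate the two.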